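This account rests on a few compounds, and the source may have more. Where it says the series, first, only, none or still open, it means among the compounds named here.

In a functional assay on PANC-1 cells (Homo sapiens) for inhibition, read by MTT assay, with a stated time of 24 h (on this read-out lower numbers stand for stronger inhibition and higher numbers for weaker inhibition), compound 1 `CC1(C)[C@H]2CC[C@]1(C)N(Cc1cn(-c3cccc(C#N)c3)nn1)C(=O)C2` gives 260 nM and compound 2 `CC1(C)[C@H]2CC[C@]1(C)N(Cc1cn(-c3ccc(Br)cc3)nn1)C(=O)C2` gives 200 nM. Going by the values given here, these are the only two numbers so far, and they cannot be told apart, so compound 2 holds no clear place over compound 1. Compound 3 `CC1(C)[C@H]2CC[C@]1(C)N(Cc1cn(-c3cccc(Br)c3)nn1)C(=O)C2` has 3-bromophenyl in place of 4-bromophenyl on an aromatic nitrogen, the same atoms joined differently: 3-bromophenyl in place of 4-bromophenyl on an aromatic nitrogen. Among the compounds with values here, only one measured step bears on this change. That step is a 1.3-fold lower number from compound 1 to compound 2 (0.11 log units; within the scatter), and it put 4-bromophenyl in place of 3-cyanophenyl on an aromatic nitrogen. With a single small step as the guide, no change beyond the scatter is expected in this assay, and no firm direction can be given. The expected size is a 1.2-fold higher number from compound 2 to compound 3 (0.06 log units; within the scatter). The estimate for compound 3 is 230 nM, with an expected range from 110 nM to 470 nM.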

Compound 3, half-maximal inhibitory concentration: 90 nM
For compound 3 the middle estimate is 2.6-fold (0.41 log units) above the measured one, outside the stated range (below it).
By their numbers in this assay, from the lowest: compound 3; then compounds 2 and 1 (each within the scatter of the next).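

In this assay, the place of the bromine on the phenyl ring matters by itself: with the same atoms, 3-bromophenyl in place of 4-bromophenyl gives a modest gain in inhibition (a 2.2-fold lower number from compound 2 to compound 3 (0.35 log units; beyond the scatter)). The group matters as well, since bromo in place of cyano, with the place kept, also gives a modest gain (a 2.9-fold lower number from compound 1 to compound 3 (0.46 log units; beyond the scatter)). The earlier step from 3-cyanophenyl to 4-bromophenyl changed group and place together and could not separate these two effects.

No measurement given here explains why 3-bromophenyl gives the lowest number of the three. As far as these compounds go, it also remains open whether another group in place of the bromo on 3-bromophenyl, such as an amine, a carboxylic acid or a longer chain, would keep, improve or lose this inhibition.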